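The compounds below may be only part of what the source reports. "The series", "measured", "known", "first", "only" and "open" are said of these compounds alone.

The shared core is that of compound 1, `COc1cc(/C=C/C(=O)N2CCC=CS2(=O)=O)cc(OC)c1OC`, which in a functional assay on HeLa cells (Homo sapiens) for inhibition, read by sulforhodamine B assay, with a stated time of 48 h (on this read-out lower numbers stand for stronger inhibition of growth and higher numbers for weaker inhibition of growth), gives 14300 nM. Compound 2, `O=C(/C=C/c1cccs1)N1CCC=CS1(=O)=O`, gives 18800 nM in this assay, and the two values lie within the usual scatter of each other. Compound 3, `O=C(/C=C/c1cccc(F)c1)N1CCC=CS1(=O)=O`, is reported in this assay only as a limit, < 100 nM, and not as a number. This limit is the one described by the limit of < 100 nM in this assay, at which 1 of the 3 values shown sits. Compound 3 therefore stands well apart from compound 1 and compound 2, whose numbers are far higher. Compound 4, `Cc1cccc(/C=C/C(=O)N2CCC=CS2(=O)=O)c1`, differs from compound 3 by methyl in place of fluoro on an aromatic carbon. Going by the values given here, no measured pair shows such an exchange, so the size of the step cannot be read from the data, and the limit on compound 3 leaves its starting point open. The expected step in this assay is an at least 4.0-fold higher number from compound 3 to compound 4 (0.60 log units; beyond the scatter), toward somewhat weaker inhibition, possibly not beyond the scatter. Compound 4 is accordingly expected to give about 400 nM in this assay, within a range from 60 nM to 4000 nM.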

Compound 4, concentration for 50% growth inhibition: 20700 nM
Compound 4: the middle estimate sits 52-fold (1.71 log units) below what was measured; measured number above the stated range.
By their numbers in this assay, from the lowest: compounds 1, 2 and 4 (each within the scatter of the next). At a limit, below all of these: compound 3.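

On an aromatic carbon of a six-membered aromatic ring of carbon only, meta to a large group, methyl in place of fluoro gives an at least 200-fold higher number from compound 3 to compound 4 (2.31 log units; beyond the scatter) in this assay. Going by these compounds alone, this is the first step that can be read from a pair differing in one place, and it shows that exchanging one heavy atom for another at this position is enough to produce a large change in growth inhibition. Compound 3 is reported only as a limit, so the printed step is a minimum and its full size stays open: the limit of < 100 nM in this assay, at which 1 of the 4 values shown sits.

From the compounds shown here alone, with a single pair, it remains open whether fluoro is unusual at this position or methyl is unfavourable there. Nor do the compounds shown tell whether hydrogen, chloro, methoxy or an amine on that same carbon would fall nearer compound 3 or compound 4.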